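Methyl added at the ring nitrogen chain of compound 3

The source may hold more compounds than are shown below. What is called first, only, known or untested is meant among the compounds shown, and "the series" means these compounds.

Compound 1 `CCn1c(-c2ccccc2)nc2c(NC3CCC3)ncnc21` gives 84 nM in an assay on CHO cells for displacement of a labelled ligand from adenosine receptor A3 (Homo sapiens), read by scintillation counting, with a stated time of 3 h; a higher number here means a weaker inhibitor, a lower number a stronger inhibitor. Compound 2 `CCCn1c(-c2ccccc2)nc2c(NC3CCC3)ncnc21` gives 264 nM, and the change methyl in place of hydrogen on a saturated chain carbon, two bonds along the chain from an aromatic nitrogen produced a 3.1-fold higher number from compound 1 to compound 2 (0.50 log units; beyond the scatter). Compound 3 `Cn1c(-c2ccccc2)nc2c(NC3CCCC3)ncnc21` gives 846 nM, the highest number of the three; how its core differs from that of compound 1 is not broken down here. Compound 4 `CCn1c(-c2ccccc2)nc2c(NC3CCCC3)ncnc21` differs from compound 3 by methyl in place of hydrogen on a saturated chain carbon bound to an aromatic nitrogen. This is the same kind of change as that from compound 1 to compound 2, but not the same: there the methyl entered two bonds along the chain from an aromatic nitrogen, here it enters on a saturated chain carbon bound to an aromatic nitrogen. Resting only on the earlier step of a 3.1-fold higher number from compound 1 to compound 2 (0.50 log units; beyond the scatter), a smaller shift is expected for compound 4, namely a 1.2-fold higher number from compound 3 to compound 4 (0.07 log units; within the scatter), with an estimated value of 1000 nM between 300 nM and 3000 nM.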

Compound 4, inhibition constant: 354 nM
For compound 4 the middle estimate is 2.8-fold (0.45 log units) above the measured one; the measured number falls inside the stated range.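

In this assay, methyl in place of hydrogen on a saturated chain carbon bound to an aromatic nitrogen gives a 2.4-fold lower number from compound 3 to compound 4 (0.38 log units; beyond the scatter) while cyclopentyl in place of cyclobutyl on a nitrogen on an aromatic ring gives a 4.2-fold higher number from compound 1 to compound 4 (0.62 log units; beyond the scatter). Adding a methyl to the chain therefore does not carry over unchanged from one core to the other, and the two steps run in opposite directions: the same change on two cores in this assay, a 3.1-fold higher number (0.50 log units; beyond the scatter) from compound 1 to compound 2 and a 2.4-fold lower number (0.38 log units; beyond the scatter) from compound 3 to compound 4, 7.5-fold (0.88 log units) apart, beyond the scatter of two such steps. Within the data shown here, these are only two pairs, and the methyl enters at a different place in each, so they do not separate the effect of the core from that of the place.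

The compounds shown leave open how a propyl chain would behave alongside cyclopentyl. Also open, from the compounds shown here alone, is whether a butyl chain, or cyclohexyl in place of cyclopentyl, would follow either trend.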